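Methoxy Added Beside Fluorine on the Ring Nitrogen Aryl

The source may hold more compounds than are shown below. What is called first, only, known or untested is meant among the compounds shown, and "the series" means these compounds.

Measured compounds:
compound 1, `COc1ccc(OC)c(N2C(=O)CSC2c2cccc(C(=O)NCCCCc3ccccc3)c2)c1`, 92%;
compound 2, `O=C(NCCCCc1ccccc1)c1cccc(C2SCC(=O)N2c2cccc(F)c2)c1`, 92%.

Both compounds share one core and differ only in the aryl group on the amide-type nitrogen in the ring. In a functional assay on MG-63 cells (Homo sapiens) for inhibition, read by CCK-8 assay, with a stated time of 72 h, tested at 1 uM (on this read-out lower numbers stand for less inhibition and higher numbers for more inhibition at the one concentration tested (going by the name of the read-out)), compound 1 gives 92%, and compound 2 gives 92%. Among the compounds with values here, the one step that has been measured, no change at the digits printed from compound 1 to compound 2 (within the scatter), replaced the whole aryl group, 3-fluorophenyl in place of 2,5-dimethoxyphenyl, and left the read-out where it was. Compound 2 therefore stands level with compound 1 at the digits shown, and both sit near the top of the scale at this concentration.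

The next compound, compound 3, `COc1c(F)cccc1N1C(=O)CSC1c1cccc(C(=O)NCCCCc2ccccc2)c1`, is not yet measured. It differs from compound 2 by methoxy in place of hydrogen on an aromatic carbon, on an aromatic carbon ortho to a fluoro group and ortho to a large group; cut one bond further out, 3-fluorophenyl becomes 3-fluoro-2-methoxyphenyl.

Within the data shown here, only the step from compound 1 to compound 2 bears on this change, and it was within the scatter even though it swapped the entire aryl group. A smaller change on the same ring is expected to move this assay no more than that, so the step of a number 2 percentage points lower from compound 2 to compound 3 (within the scatter) is estimated to lie within the scatter. Compound 3 is expected to give 90%, in a range of 80% to 97%.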

Compound 3, a percentage reported as inhibition, at one concentration (the size of the read-out at that concentration, not a potency): 0%
For compound 3 the middle estimate is 90 percentage points above the measured one; the measured number lies below the stated range.
By their numbers in this assay, from the lowest: compound 3; then compounds 1 and 2 (each within the scatter of the next).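

The step of a number 92 percentage points lower from compound 2 to compound 3 (beyond the scatter) in this assay shows that this aromatic carbon, ortho to a fluoro group and ortho to a large group, is far more sensitive than the earlier pair suggested, since a change of only 2 heavy atoms here outweighs the exchange of the whole aryl group that left the read-out in place. The step of a number 92 percentage points lower from compound 1 to compound 3 (beyond the scatter) adds that a methoxy at this place does not by itself go with the loss, as the 2,5-dimethoxyphenyl of compound 1 also carries one and compound 1 stays at 92%. Among these three compounds, the loss is therefore seen only for the 3-fluoro-2-methoxyphenyl combination, and the read-out on this ring cannot be taken from either group alone.

The compounds shown leave open whether a hydroxy group, an ethoxy group or a chlorine atom at this same carbon, or a methoxy on another carbon of the 3-fluorophenyl ring, would keep the read-out or lose it as compound 3 does. Nothing available explains why the read-out falls at this change.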